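The compounds below may be only part of what the source reports. "The series", "measured", "known", "first", "only" and "open" are said of these compounds alone.

Working notes on the series. Compound 2 `CC1CC(=O)N(c2ccccc2C(=O)OCC2CCCN(CCCCCOc3ccccc3)C2)C1=O` and compound 3 `COc1ccc(OCCCCCN2CCCC(COC(=O)c3ccccc3N3C(=O)CC(C)C3=O)C2)cc1OC` share one core and differ only in the aryl group on the oxygen at the end of the chain; compound 1 `O=C(OCC1CCCN(CCCc2ccccc2)C1)c1ccc(-c2ccccc2)cc1` belongs to a different branch of the set. In an in vitro functional assay on HEK ts201 cells for antagonist activity at Neuronal acetylcholine receptor; alpha4/beta2 (Homo sapiens), read by fluorescence and calcium flux (a lower number here means a stronger inhibitor, a higher number a weaker inhibitor), compound 1 gives 6310 nM, compound 2 gives 17000 nM and compound 3 gives 8320 nM. Compound 3 thus stands second highest of the three numbers: its gap to compound 1 lies within the scatter, while its gap to compound 2 lies beyond it. Among the measured compounds shown here, the one measured step that alters the aryl group on that oxygen, a 2.0-fold lower number from compound 2 to compound 3 (0.31 log units; beyond the scatter), is modest in size. Compound 4 `CC1CC(=O)N(c2ccccc2C(=O)OCC2CCCN(CCCCCOc3ccc(Cl)c(Cl)c3)C2)C1=O` continues at the same place: 3,4-dichlorophenyl in place of 3,4-dimethoxyphenyl on an oxygen on a saturated carbon. For the measured compounds named here, no measured pair swaps 3,4-dimethoxyphenyl for 3,4-dichlorophenyl, so the only bearing comes from the earlier aryl change, which moved the number modestly; for this assay a step of similar size or none beyond the scatter is expected, with the direction uncertain. The estimated step, a 1.4-fold lower number from compound 3 to compound 4 (0.14 log units; within the scatter), is accordingly small. Compound 4 is expected to give about 6000 nM, between 2500 nM and 15000 nM.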

Compound 4, half-maximal inhibitory concentration: 17400 nM
Beside the measured number, compound 4's estimate is 2.9-fold (0.46 log units) below it, outside the stated range (above it).
By their numbers in this assay, from the lowest: compounds 1 and 3 (each within the scatter of the next); then compounds 2 and 4 (each within the scatter of the next).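

In this assay, the aryl group on the oxygen now has three members, and only 3,4-dimethoxyphenyl stands apart. 3,4-Dichlorophenyl in place of 3,4-dimethoxyphenyl gives a 2.1-fold higher number from compound 3 to compound 4 (0.32 log units; beyond the scatter), while 3,4-dichlorophenyl in place of phenyl gives a 1.0-fold higher number from compound 2 to compound 4 (0.01 log units; within the scatter), so the dichloro pattern leaves the number where phenyl had it and substitution of the ring as such does not lower it. Nothing measured here accounts for the difference between the two substituted rings.

Open, on these data alone, is whether the lower number needs both methoxy groups, which a single methoxy group on the phenyl ring would test. Also open, as far as these compounds go, is whether the same order of aryl groups holds with a shorter chain on the ring nitrogen.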